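The source may report more compounds than this note shows. Statements on the series, on what has been measured and on what is new or still open speak of the compounds shown alone.

Measured in a functional assay on HL-60 cells (Homo sapiens) for antiproliferative activity, read by MTT assay, with a stated time of 48 h; a lower number here means a stronger inhibitor, a higher number a weaker inhibitor:
- Compound 1 `CC(C)=CCC[C@]1(C)/C=C/[C@@H](OC(=O)C=C(C)C)[C@](C)(O)/C=C/C(=O)/C(C(=O)O)=C\C1`: > 10000 nM, a limit of the assay
- Compound 2 `CC(C)=CCC[C@]1(C)/C=C/[C@@H](OC(=O)C=C(C)C)[C@](C)(O)/C=C/C(=O)/C(CN2CCCC2)=C\C1`: 160 nM
- Compound 3 `CC(C)=CCC[C@]1(C)/C=C/[C@@H](OC(=O)C=C(C)C)[C@](C)(O)/C=C/C(=O)/C(CN=[N+]=[N-])=C\C1`: 910 nM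

Compound 3 carries the higher of the two actual numbers, 910 nM, and the gap between those two is a 5.7-fold higher number from compound 2 to compound 3 (0.75 log units; beyond the scatter). Compound 4 `CC(C)=CCC[C@]1(C)/C=C/[C@@H](OC(=O)C=C(C)C)[C@](C)(O)/C=C/C(=O)/C(Cn2cc(CO)nn2)=C\C1` keeps the shared core and differs at one place, a saturated chain carbon bound to a double-bonded ring carbon, where 4-(hydroxymethyl)-1H-1,2,3-triazol-1-yl stands in place of azido: 4-(hydroxymethyl)-1H-1,2,3-triazol-1-yl in place of azido on a saturated chain carbon bound to a double-bonded ring carbon.

Going by the values given here, three measured steps bear on this change. Two are large, an at least 62-fold lower number from compound 1 to compound 2 (1.79 log units; beyond the scatter) and an at least 10-fold lower number from compound 1 to compound 3 (1.04 log units; beyond the scatter), and the third is modest, a 5.7-fold higher number from compound 2 to compound 3 (0.75 log units; beyond the scatter). So this part of the molecule clearly responds to substitution, but none of these compounds holds a triazole, and the direction stays uncertain. A modest step towards a higher number in this assay is expected, starting from compound 3 at 910 nM. The expected change is a 1.6-fold higher number from compound 3 to compound 4 (0.22 log units; within the scatter). For compound 4 the estimated value is 1500 nM, with an expected range from 400 nM to 6000 nM.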

Compound 4, half-maximal inhibitory concentration: 3200 nM
Estimate against measurement, compound 4: 2.1-fold (0.33 log units) below, within the range that was stated.
By their numbers in this assay, from the lowest: compound 2; then compound 3; then compound 4. At a limit, above all of these: compound 1.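

Exchanging azido for 4-(hydroxymethyl)-1H-1,2,3-triazol-1-yl gives a 3.5-fold higher number from compound 3 to compound 4 (0.55 log units; beyond the scatter) in this assay, so this aromatic ring group at this place weakens the compound rather than matching azido. Set against pyrrolidin-1-yl, the same group gives a 20-fold higher number from compound 2 to compound 4 (1.30 log units; beyond the scatter) and ranks lowest in strength of the three groups on this saturated chain carbon, with every step among them beyond the scatter. Compound 4 still gives a measured number, and an at least 3.1-fold lower number from compound 1 to compound 4 (0.49 log units; beyond the scatter) can be read only as a bound set by the limit of compound 1: the limit of > 10000 nM in this assay, at which 1 of the 4 values shown sits.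

As far as these compounds go, whether the loss belongs to the triazole ring or to its hydroxymethyl group stays open; a triazole carrying a plain methyl or a phenyl group would separate the two. From the compounds shown here alone, whether the strength of compound 2 is particular to pyrrolidin-1-yl also stays open, and a piperidine or a dimethylamino group at this place would test it.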